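A Carbamate in Place of a Thiophene Amide

The source may hold more compounds than are shown below. What is called first, only, known or untested is meant among the compounds shown, and "the series" means these compounds.

The compounds here share one core and differ in the groups attached to it. Compound 1 `CN(C)c1cc2[nH]c(C3CCCCC3)nc2cc1NC(=O)c1cccs1` carries a thiophen-2-yl group on an amide carbonyl. In an ADME assay on Vero cells (Chlorocebus sabaeus) for cytotoxicity, read by resazurin assay, with a stated time of 3 days (a higher number here means a weaker inhibitor, a lower number a stronger inhibitor), compound 1 gives > 100 ug/mL, which is a limit of the assay rather than a measured number. Two further compounds give the same limit. Compound 2 `COCCOC(=O)Nc1cc2nc(C3CCCCC3)[nH]c2cc1N1CCCC1` in this assay gives > 100 ug/mL, again a limit. Compound 3 `CCCCOC(=O)Nc1cc2nc(C3CCCCC3)[nH]c2cc1N(CC)CCN(C)C` in this assay gives > 100 ug/mL, also a limit. All three sit at the limit of > 100 ug/mL in this assay, at which 3 of the 3 values shown sit, so compound 1 stands level with the others as far as the numbers can tell, and no ordering among them is possible.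

Compound 4 `CN(C)c1cc2[nH]c(C3CCCCC3)nc2cc1NC(=O)OCc1ccccc1` has not yet been measured. It differs from compound 1 by benzyloxy in place of thiophen-2-yl on a carbonyl carbon. Among the compounds with values here, no step between measured compounds is available, so the effect of such a change cannot be read from any measured pair. Every measured compound sits at the limit of > 100 ug/mL in this assay, at which 3 of the 3 values shown sit, so the expectation is that compound 4 also reaches that limit, and the step that the limit leaves unreadable from compound 1 to compound 4 is expected to be none beyond the scatter. Compound 4 is expected to give about 150 ug/mL, with a range from 60 ug/mL to 400 ug/mL, most likely again reported as a limit.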

Compound 4, half-maximal inhibitory concentration: > 100 ug/mL
Compound 4 was reported as a limit; the forecaster's own chance of this, stated with the estimate: 85%; the middle value lies beyond the limit too.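

Compound 1 and compound 4 are both reported only as limits in this assay and so no new step can be read between them. The compounds shown leave open how far each lies past that limit, and so whether benzyloxy in place of thiophen-2-yl on a carbonyl carbon changes the read-out at all.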